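This account rests on a few compounds, and the source may have more. Where it says the series, first, only, none or still open, it means among the compounds named here.

Compound 3 `NC(=O)c1cccc(-c2cnc(C(=O)CCc3ccc(-c4ccccc4)cc3)o2)n1` gives 1.2 nM in an assay for inhibition of Fatty-acid amide hydrolase 1 (Rattus norvegicus); a lower number here means a stronger inhibitor, a higher number a weaker inhibitor. Compound 1 `N#Cc1cccc(-c2cnc(C(=O)CCc3ccc(-c4ccccc4)cc3)o2)n1` differs from it in one place, (cyano in place of carbamoyl on an aromatic carbon), and in this assay compound 1 gives 2.9 nM, a step of a 2.4-fold higher number from compound 3 to compound 1 (0.38 log units; beyond the scatter). Compound 2 `NC(=O)c1cnc(C(=O)CCc2ccc(Oc3ccccc3)cc2)o1` gives 6.6 nM in this assay; the difference between its core and the core of compound 3 is not broken down here. Compound 4 `N#Cc1cnc(C(=O)CCc2ccc(Oc3ccccc3)cc2)o1` is not yet measured and carries the same kind of change from compound 2, (cyano in place of carbamoyl on an aromatic carbon), the second of two such pairs. The place differs: in compound 4 the aromatic carbon sits in a five-membered aromatic ring with 1 nitrogen and 1 oxygen, next to the ring oxygen, whereas in compound 1 it sits in a six-membered aromatic ring with 1 nitrogen, next to the ring nitrogen, meta to a large group. Resting on the single step of a 2.4-fold higher number from compound 3 to compound 1 (0.38 log units; beyond the scatter), compound 4 is expected to show a step of a 2.3-fold higher number from compound 2 to compound 4 (0.36 log units; beyond the scatter) in this assay. Compound 4 is therefore estimated at 15 nM, between 6 nM and 40 nM.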

Compound 4, inhibition constant: 0.8 nM
Compound 4: the middle estimate sits 19-fold (1.27 log units) above what was measured; measured number below the stated range.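

In this assay, cyano in place of carbamoyl gave an 8.3-fold lower number from compound 2 to compound 4 (0.92 log units; beyond the scatter), and this does not match the step seen on the other core: the same change on two cores in this assay, a 2.4-fold higher number (0.38 log units; beyond the scatter) from compound 3 to compound 1 and an 8.3-fold lower number (0.92 log units; beyond the scatter) from compound 2 to compound 4, 20-fold (1.30 log units) apart, beyond the scatter of two such steps The change therefore does not carry from one core to another in this series as a fixed step: it raises the number on one core and lowers it on the other. These two pairs do not show what sets the difference, as the place of the change and the rest of the molecule differ together.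

The compounds shown leave open whether a carboxylic acid or a methyl ester on the same aromatic carbon would track the cyano or the carbamoyl group. They also leave open how large the step would be if the place stayed fixed and only the rest of the molecule changed.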